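A few compounds are considered here, and "the series" means these few. Any claim that something is new, unique, unknown or untested is made for them only; others in the source may bear on it.

Compound 3 `Cn1cc(C(=O)Nc2ccc(-c3ccncc3)c(C(F)(F)F)c2)c(=O)c2ccccc21` gives 6.4 ug/mL in a physicochemical assay for solubility, at pH 7.4; a higher number here means a more soluble compound, a lower number a less soluble compound. Compound 2 `Cn1cc(C(=O)Nc2ccc(-c3ccccn3)c(C(F)(F)F)c2)c(=O)c2ccccc21` gives 12 ug/mL in this assay, and the step from compound 2 to compound 3 was a 1.9-fold lower number from compound 2 to compound 3 (0.27 log units; within the scatter). Compound 1 `Cn1cc(C(=O)Nc2ccc(-c3ccccc3)c(C(F)(F)F)c2)c(=O)c2cnccc21` sits at a limit of this assay, < 1 ug/mL, which is the limit of < 1 ug/mL in this assay, at which 1 of the 3 values shown sits. Of the two numbers shown, compound 3 stands lowest, with compound 2 nearest, though that gap lies within the scatter. Compound 4 `Cn1cc(C(=O)Nc2ccc(-c3cccnc3)c(C(F)(F)F)c2)c(=O)c2ccccc21` differs from compound 3 by pyridin-3-yl in place of pyridin-4-yl on an aromatic carbon. Going by the values given here, the only measured step that bears on this change is the one between compound 2 and compound 3, and it stayed within the scatter. For compound 4 a step of a 1.1-fold higher number from compound 3 to compound 4 (0.04 log units; within the scatter) is therefore expected, none beyond the scatter. Compound 4 is estimated at 7 ug/mL, within a range from 2.5 ug/mL to 20 ug/mL.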

Compound 4, solubility: 23 ug/mL
Compound 4: the middle estimate sits 3.3-fold (0.52 log units) below what was measured; the whole stated range lies below it.
By their numbers in this assay, from the lowest: compounds 3, 2 and 4 (each within the scatter of the next, the first and the last beyond it). At a limit, below all of these: compound 1.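

In this assay, going by these compounds alone, pyridin-3-yl in place of pyridin-4-yl gave a 3.6-fold higher number from compound 3 to compound 4 (0.56 log units; beyond the scatter), the only step among the three pyridinyl compounds that lies beyond the scatter. Pyridin-3-yl in place of pyridin-2-yl gave a 1.9-fold higher number from compound 2 to compound 4 (0.28 log units; within the scatter), so at this carbon, ortho to a trifluoromethyl group, swapping one pyridinyl isomer for another can give a step beyond the scatter, but only for this one pair. Nothing shown explains the difference. Still open, as far as these compounds go, is how a morpholine or a carboxylic acid on the pyridine ring would read in this assay.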